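Morpholine Amide in Place of a Carboxylic Acid

The compounds below may be only part of what the source reports. "The series", "measured", "known", "first", "only" and "open" are said of these compounds alone.

Measured so far:
compound 1 `CCCn1c(SCc2cccc(C)c2)nc2c1c(=O)[nH]c(=O)n2C`: 84.1%
compound 2 `Cn1cnc2c1c(=O)n(CC(=O)O)c(=O)n2C`: 0.8%

Of the compounds shown here, two have been tested in a functional assay on MGC-803 cells (Homo sapiens) for inhibition, read by MTT assay, with a stated time of 48 h, tested at 20 uM; on this read-out higher numbers stand for more inhibition at the one concentration tested (going by the name of the read-out) and lower numbers for less inhibition. Compound 1 gives 84.1% in this assay, while compound 2 gives 0.8%, the lowest of the two numbers; its nearest neighbour is compound 1, whose value lies far above it, a gap well beyond the scatter. For the measured compounds named here, the two structures differ in several places at once, so no single step is recorded between them.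

Compound 3 `Cn1cnc2c1c(=O)n(CC(=O)N1CCOCC1)c(=O)n2C` is the next compound, not yet measured in this assay. It differs from compound 2 by morpholin-4-yl in place of hydroxy on a carbonyl carbon. Going by the values given here, no measured pair shows this change, so its effect is unknown. With compound 2 sitting at the bottom of the range, the step from compound 2 to compound 3 is expected to be small, a number 7.2 percentage points higher from compound 2 to compound 3 (within the scatter), and most likely not beyond the scatter. Compound 3 is therefore estimated at 8%, in a range from 0% to 30%.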

Compound 3, a percentage reported as inhibition, at one concentration (the size of the read-out at that concentration, not a potency): 19.9%
The estimate for compound 3 lay 11.9 percentage points below the measured number; the range from low to high includes it.
By their numbers in this assay, from the lowest: compound 2; then compound 3; then compound 1.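

In this assay, for the compounds shown here, morpholin-4-yl in place of hydroxy on a carbonyl carbon gives a number 19.1 percentage points higher from compound 2 to compound 3 (beyond the scatter), the first change at a single place that can be read. It shows that the number at this position responds to what sits on the carbonyl carbon, and that the carboxylic acid of compound 2 is not needed for the modest inhibition seen with compound 3, though this one step cannot show a trend. No measurement on hand bears on why the number moved.

As far as these compounds go, whether piperidine, dimethylamine or a methyl ester on the same carbonyl carbon would move the number further remains open. Compound 1 differs from compound 2 and compound 3 in several places at once, so what separates its value from theirs cannot be read from the compounds shown.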